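Removing a chain double bond from compound 3

A few compounds are considered here, and "the series" means these few. Any claim that something is new, unique, unknown or untested is made for them only; others in the source may bear on it.

Compound 1 `CCCCCCCC/C=C\CCCCCCCC(=O)N1CCCC1` gives 3.8 ug/mL 
Compound 2 `CCCCCCCCCCCCCCCCCC(=O)N[C@H](C)c1ccccc1` gives 161 ug/mL 
Compound 3 `CCCCC/C=C\C/C=C\CCCCCCCC(=O)N1CCCCC1` gives 44.2 ug/mL 

In a functional assay on U-251 cells (Homo sapiens) for antiproliferative activity, read by sulforhodamine B assay, with a stated time of 48 h (on this read-out higher numbers stand for weaker inhibition of growth and lower numbers for stronger inhibition of growth), compound 3 stands second highest of the three, below compound 2 and above compound 1, with both gaps beyond the scatter. The change to compound 4 `CCCCCCCC/C=C\CCCCCCCC(=O)N1CCCCC1` is heptyl in place of hept-1-en-1-yl on a saturated chain carbon bound to a double-bonded chain carbon. For the measured compounds named here, no measured pair shows this change alone. Compound 1 (3.8 ug/mL) carries the same chain as compound 4 on a different amide, so a step to a lower number, beyond the scatter, is expected in this assay with much uncertainty. The expected step is a 2.9-fold lower number from compound 3 to compound 4 (0.47 log units; beyond the scatter) in size. Compound 4 is estimated at 15 ug/mL (expected range 4 ug/mL to 60 ug/mL).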

Compound 4, concentration for 50% growth inhibition: 6.7 ug/mL
Compound 4: the middle estimate sits 2.2-fold (0.35 log units) above what was measured; measured number inside the range.
By their numbers in this assay, from the lowest: compounds 1 and 4 (each within the scatter of the next); then compound 3; then compound 2.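

In this assay, for the compounds shown here, heptyl in place of hept-1-en-1-yl on a saturated chain carbon bound to a double-bonded chain carbon gives a 6.6-fold lower number from compound 3 to compound 4 (0.82 log units; beyond the scatter) and so offers the first direct reading of this change, with the amide held constant. Piperidin-1-yl in place of pyrrolidin-1-yl on a carbonyl carbon gives a 1.8-fold higher number from compound 1 to compound 4 (0.25 log units; within the scatter) so that, with this chain, the two amides cannot be told apart. No evidence available here explains either step. From the compounds shown here alone, whether the remaining double bond matters stays open. So does how a morpholin-4-yl group or a longer chain would fare on the carbonyl carbon.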